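Compound 3 against compound 2 at the ether position

The compounds below may be only part of what the source reports. "The series", "measured", "known", "first", "only" and "open" are said of these compounds alone.

Compound 2 `CC(C)[C@H](NC(=O)COc1cccc2ccccc12)C(=O)N[C@@H](CC(=O)O)C(=O)COc1nccc(C(F)(F)F)n1` stands at the edge of what a functional assay on Jurkat cells (Homo sapiens) for inhibition (a higher number here means a weaker inhibitor, a lower number a stronger inhibitor), can report: in this assay compound 2 gives > 200000 nM, which is a limit of the assay and not a number. Among the measured compounds shown here, the only other measured member is compound 1 `COC(=O)c1cc(OCC(=O)[C@H](CC(=O)O)NC(=O)[C@@H](NC(=O)COc2cccc3ccccc23)C(C)C)no1`; in this assay compound 1 gives 71000 nM. One step connects them, at the same oxygen on a saturated carbon: an at least 2.8-fold higher number from compound 1 to compound 2 (0.44 log units; beyond the scatter). Its size is bounded on one side only because of the limit of > 200000 nM in this assay, at which 1 of the 2 values shown sits.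

Compound 3 `CC(C)[C@H](NC(=O)COc1cccc2ccccc12)C(=O)N[C@@H](CC(=O)O)C(=O)COc1[nH]cnc2nncc1-2` alters that same position once more: a group of 9 heavy atoms (5 carbon, 4 nitrogen; one five-membered aromatic ring with 2 hetero atoms, one six-membered aromatic ring with 2 hetero atoms) in place of a group of 10 heavy atoms (5 carbon, 2 nitrogen, 3 fluorine; one six-membered aromatic ring with 2 hetero atoms), on an oxygen on a saturated carbon. For the measured compounds named here, no measured step covers this exchange. Going by the values given here, the single step at this position, from the 5-(methoxycarbonyl)-1,2-oxazol-3-yl group to the 4-(trifluoromethyl)pyrimidin-2-yl group, shows that changes here move the read-out by an at least modest amount, but it gives no direction for the entering group. Since compound 2 is only a limit, the expected step of an at least 1.3-fold lower number from compound 2 to compound 3 (0.12 log units; that floor lies within the scatter) is itself uncertain in sign and size. The estimate for compound 3 in this assay is 150000 nM, expected to fall between 30000 nM and 600000 nM, with a real chance that only a limit is reported again.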

Compound 3, half-maximal inhibitory concentration: 161000 nM
Estimate against measurement, compound 3: 1.1-fold (0.03 log units) below, and the stated range covers the measured number.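

Compound 3 gives this position a second measured comparison in this assay: a 2.3-fold higher number from compound 1 to compound 3 (0.36 log units; beyond the scatter), so compound 1, with its 5-(methoxycarbonyl)-1,2-oxazol-3-yl group, keeps the lowest number of the three. Against the 4-(trifluoromethyl)pyrimidin-2-yl group, the reading is an at least 1.2-fold lower number from compound 2 to compound 3 (0.09 log units; that floor lies within the scatter); that floor lies within the scatter, so it sets no order between the two groups. The true size of this step stays unknown because the value for compound 2 is a limit and not a number: the limit of > 200000 nM in this assay, at which 1 of the 3 values shown sits.

The compounds shown do not separate the contribution of the methoxycarbonyl group from that of the 1,2-oxazole ring that carries it, and a carboxylic acid or a primary amide in place of the methyl ester would put that question to the test. On these data alone, it also remains open whether a plain phenyl group on this oxygen would give a number nearer to that of compound 1 or to those of the other two compounds, all on the same shared core.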